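This account rests on a few compounds, and the source may have more. Where it says the series, first, only, none or still open, it means among the compounds named here.

Compound 1 `COc1cc2c(Nc3ccc(C#N)cc3)ncnc2cc1OCCCN1CCCC1` is the shared core carrying a pyrrolidin-1-yl group. In a functional assay on A549 cells (Homo sapiens) for antiproliferative activity, read by MTT assay, with a stated time of 72 h (a lower number here means a stronger inhibitor, a higher number a weaker inhibitor), compound 1 gives 21800 nM, the lowest of the two numbers available. Compound 2 `COc1cc2c(Nc3ccc(C#N)cc3)ncnc2cc1OCCCN1CCC(C)CC1` gives 32300 nM in this assay, and a 1.5-fold higher number from compound 1 to compound 2 (0.17 log units; within the scatter). Compound 3 `COc1cc2c(Nc3ccc(C#N)cc3)ncnc2cc1OCCCN1CCc2ccccc2C1` reports only a limit of the assay, > 100000 nM. Accordingly, an at least 4.5-fold higher number from compound 1 to compound 3 (0.66 log units; beyond the scatter), the larger group weakening the inhibitor. Compound 4 `COc1cc2c(Nc3ccc(C#N)cc3)ncnc2cc1OCCCN1CCC(N2CCCCC2)CC1` differs from compound 1 by 4-(piperidin-1-yl)piperidin-1-yl in place of pyrrolidin-1-yl on a saturated chain carbon, three bonds along the chain from an oxygen on an aromatic ring. Since the larger group in compound 3 gave an at least 4.5-fold higher number from compound 1 to compound 3 (0.66 log units; beyond the scatter) while the modest enlargement in compound 2 gave a 1.5-fold higher number from compound 1 to compound 2 (0.17 log units; within the scatter), a weakening beyond the scatter is expected for compound 4, though a saturated group may cost less. The expected step is a 2.1-fold higher number from compound 1 to compound 4 (0.31 log units; beyond the scatter). Compound 4 is estimated at 45000 nM, between 18000 nM and 110000 nM.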

Compound 4, half-maximal inhibitory concentration: 30700 nM
Beside the measured number, compound 4's estimate is 1.5-fold (0.17 log units) above it; the measured number falls inside the stated range.
By their numbers in this assay, from the lowest: compounds 1, 4 and 2 (each within the scatter of the next). At a limit, above all of these: compound 3.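

In this assay, heavy-atom count alone does not track the number at this position: 4-(piperidin-1-yl)piperidin-1-yl, with 12 heavy atoms against 5 for pyrrolidin-1-yl, gives a 1.4-fold higher number from compound 1 to compound 4 (0.15 log units; within the scatter), and piperidin-1-yl in place of methyl on a saturated ring carbon gives a 1.1-fold lower number from compound 2 to compound 4 (0.02 log units; within the scatter). Compound 3 goes against this flat picture, with an at least 3.2-fold lower number from compound 3 to compound 4 (0.51 log units; beyond the scatter). Compound 3 remains a limit of the assay, not a number: the limit of > 100000 nM in this assay, at which 1 of the 4 values shown sits.

On these data alone, whether a morpholin-4-yl or piperazin-1-yl ring would fit this flat picture stays open. So does the effect of a longer chain carrying these rings.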